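Extending the nitrile-bearing chain on a leukotriene receptor series

A few compounds are considered here, and "the series" means these few. Any claim that something is new, unique, unknown or untested is made for them only; others in the source may bear on it.

Of the compounds shown here, three sharing one aromatic core have been measured. Compound 1 `CC(=O)c1cc(CC(C)O)c(OCCCCC#N)cc1O` carries a 2-hydroxypropyl group on the ring; in an assay on isolated protein for inhibition of leukotriene B4 receptor 1 (Homo sapiens), tested at 10 uM (on this read-out higher numbers stand for more inhibition at the one concentration tested (going by the name of the read-out) and lower numbers for less inhibition), compound 1 gives 10%. Compound 2 `CC(=O)c1cc(C=O)c(OCCCCC#N)cc1O` differs only by a formyl in place of that 2-hydroxypropyl, and in this assay compound 2 gives 6%; the step is a number 4 percentage points lower from compound 1 to compound 2 (within the scatter), so these two values cannot be told apart. Compound 3 `C=CCc1cc(C(C)=O)c(O)cc1OCCCC#N`, which bears an allyl group instead, gives 47% in this assay and stands highest of the three numbers, beyond the scatter from both compound 1 and compound 2.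

Compound 4 `C=CCc1cc(C(C)=O)c(O)cc1OCCCCCC#N` is the next compound and has not yet been measured. It differs from compound 3 in one place: 2-cyanoethyl in place of cyano on a saturated chain carbon, three bonds along the chain from an oxygen on an aromatic ring. Going by the values given here, none of the measured steps bears directly on this change; the single measured step concerns a group on the aromatic ring, not the chain that carries the nitrile, so there is no precedent here for lengthening that chain. With nothing in the data pointing either way, compound 4 is expected to give roughly the number of compound 3, a step of a number 2 percentage points lower from compound 3 to compound 4 (within the scatter) that is not expected to exceed the scatter. The estimate for compound 4 in this assay is 45%, with a range from 20% to 65%.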

Compound 4, a percentage reported as inhibition, at one concentration (the size of the read-out at that concentration, not a potency): 81%
For compound 4 the middle estimate is 36 percentage points below the measured one; the measured number lies above the stated range.
By their numbers in this assay, from the lowest: compounds 2 and 1 (each within the scatter of the next); then compound 3; then compound 4.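

The chain that carries the nitrile proves to be a place where this assay responds strongly: with the allyl group and the rest of the shared core unchanged, going from 3-cyanopropyl to 5-cyanopentyl gives a number 34 percentage points higher from compound 3 to compound 4 (beyond the scatter) on the same read-out. Going by these compounds alone, the only earlier single-place step, a number 4 percentage points lower from compound 1 to compound 2 (within the scatter), concerned a group on the aromatic ring and stayed within the scatter, so this is the first such step to move the number beyond it. Nothing measured here accounts for the size of this gain, and one step between two chain lengths does not establish a trend.

From the compounds shown here alone, it remains open whether a longer chain than 5-cyanopentyl would raise the number further, hold it or lower it, and whether the nitrile itself matters, which a carboxylic acid or an amine at the end of the chain could test. Also open, going by these compounds, is whether the same lengthening would pay off with the 2-hydroxypropyl or formyl group on the ring in place of allyl, and what potency lies behind a reading taken at a single concentration.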